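Lactam ring substitution in a bis-hydroxy ether series

This account rests on a few compounds, and the source may have more. Where it says the series, first, only, none or still open, it means among the compounds named here.

Measured so far:
Compound 1 `CCCCCCCCCC[C@H](O)COCCOC[C@@H](O)CCCCCCCCCCCCC1=C[C@H](C)N(C)C1=O`: 589 nM
Compound 2 `CCCCCCCCCC[C@H](O)COCCOC[C@@H](O)CCCCCCCCCCCCC1=CC(C)(C)N(C)C1=O`: 583 nM

In a functional assay on SK-HEP1 cells (Homo sapiens) for cytotoxicity, read by MTT assay, with a stated time of 48 h (a lower number here means a stronger inhibitor, a higher number a weaker inhibitor), compound 1 gives 589 nM and compound 2 gives 583 nM; the two sit together within the scatter, so compound 2 stands apart from nothing. Compound 3 `CCCCCCCCCC[C@H](O)COCCOC[C@@H](O)CCCCCCCCCCCCC1=CCN(C)C1=O` differs from compound 2 in a group of 7 heavy atoms (5 carbon, 1 nitrogen, 1 oxygen; one five-membered non-aromatic ring with 1 hetero atom) in place of a group of 9 heavy atoms (7 carbon, 1 nitrogen, 1 oxygen; one five-membered non-aromatic ring with 1 hetero atom), on a saturated chain carbon, ten or more bonds along the chain from an oxygen on a saturated carbon. For the measured compounds named here, the only measured step touching this ring is a 1.0-fold lower number from compound 1 to compound 2 (0.00 log units; within the scatter), which lay within the scatter. No step beyond the scatter is expected in this assay for this change. Compound 3 is therefore estimated at 600 nM, with a range of 300 nM to 1200 nM, which means an expected 1.0-fold higher number from compound 2 to compound 3 (0.01 log units; within the scatter).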

Compound 3, half-maximal inhibitory concentration: 104 nM
Beside the measured number, compound 3's estimate is 5.8-fold (0.76 log units) above it; measured number outside the range, below it.
By their numbers in this assay, from the lowest: compound 3; then compounds 2 and 1 (each within the scatter of the next).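

In this assay, hydrogen in place of methyl on the saturated ring carbon gives a 5.7-fold lower number from compound 1 to compound 3 (0.75 log units; beyond the scatter), and the group of 7 heavy atoms in place of the group of 9 heavy atoms gives a 5.6-fold lower number from compound 2 to compound 3 (0.75 log units; beyond the scatter). Compound 1 and compound 2 sit within the scatter of each other, so among these three compounds the response separates the ring carbon bearing only hydrogen from both methylated forms, not one methyl from two. Nothing on hand bears on the reason for these steps. Open, from the compounds shown here alone, is whether an ethyl or a hydroxymethyl group on that saturated ring carbon would sit with compound 1 and compound 2 or with compound 3.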